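Isopropyl in Place of Methyl: a Second Test

The source may report more compounds than this note shows. Statements on the series, on what has been measured and on what is new or still open speak of the compounds shown alone.

In an assay on HEK293 cells for antagonist activity at Voltage-dependent L-type calcium channel subunit alpha-1D (Rattus norvegicus), read by FLIPR (on this read-out higher numbers stand for weaker inhibition and lower numbers for stronger inhibition), three compounds have been measured:
Compound 1 `COC(=O)C1=C(C)NC(=O)NC1c1cccc([N+](=O)[O-])c1` gives 18900 nM.
Compound 2 `COC(=O)C1=C(C(C)C)NC(=O)NC1c1cccc([N+](=O)[O-])c1` reaches only the limit of the assay, > 100000 nM.
Compound 3 `CC1=C(C(=O)OC(C)C)C(c2cccc([N+](=O)[O-])c2)N(C(=O)OC(C)C)C(=O)N1` gives 660 nM.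

Compound 3 gives the lower number of the two numbers shown; the difference between its core and that of compound 1 is not broken down here. From compound 1 to compound 2 the change is isopropyl in place of methyl on a double-bonded ring carbon, and the step is an at least 5.2-fold higher number from compound 1 to compound 2 (0.72 log units; beyond the scatter), with compound 2 sitting at the limit of > 100000 nM in this assay, at which 1 of the 3 values shown sits.

Compound 4 `CC(C)OC(=O)C1=C(C(C)C)NC(=O)N(C(=O)OC(C)C)C1c1cccc([N+](=O)[O-])c1` is not yet measured. It differs from compound 3 by isopropyl in place of methyl on a double-bonded ring carbon. This is the same kind of change as that from compound 1 to compound 2, though the surroundings differ: in compound 3 the changed carbon is next to the ring atom that bears an isopropoxycarbonyl group and two ring bonds from the ring atom that bears a 3-nitrophenyl group, whereas in compound 1 it is next to the ring atom that bears a methoxycarbonyl group and two ring bonds from the ring atom that bears a group of 9 heavy atoms. The step from compound 3 to compound 4 is expected to be a 7.6-fold higher number from compound 3 to compound 4 (0.88 log units; beyond the scatter), resting on an at least 5.2-fold higher number from compound 1 to compound 2 (0.72 log units; beyond the scatter). Compound 4 is therefore estimated at 5000 nM, between 1500 nM and 30000 nM.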

Compound 4, half-maximal inhibitory concentration: 4310 nM
The estimate for compound 4 lay 1.2-fold (0.06 log units) above the measured number; the range from low to high includes it.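

In this assay, isopropyl in place of methyl on a double-bonded ring carbon again goes with weaker inhibition, giving a 6.5-fold higher number from compound 3 to compound 4 (0.81 log units; beyond the scatter). So the direction of the change carries over between the two cores shown, but two pairs make no general rule, and the sizes of the two steps cannot be settled: the same change on two cores in this assay, an at least 5.2-fold higher number (0.72 log units; beyond the scatter) from compound 1 to compound 2 and a 6.5-fold higher number (0.81 log units; beyond the scatter) from compound 3 to compound 4; the limit leaves it open whether they differ For compound 2, the value > 100000 nM is a limit of the assay and not a number.

The compounds shown compare only methyl and isopropyl on this carbon, so they leave open how an ethyl group, a longer chain or an amine there would read. They also leave open whether the same step would appear on any other core.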